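Replacing 5-fluoropyridin-3-yl with trifluoromethyl on the shared core

This account rests on a few compounds, and the source may have more. Where it says the series, first, only, none or still open, it means among the compounds named here.

Compound 1 `O=C(Nc1ccc(F)c(-c2nc3ncc(-c4ccc(F)c(F)c4)cc3[nH]2)c1)N1CCCC1`: 6670 nM
Compound 2 `O=C(Nc1ccc(F)c(-c2nc3ncc(-c4cncc(F)c4)cc3[nH]2)c1)N1CCCC1`: 1070 nM

Among the measured compounds shown here, in an ADME assay on the whole organism (Mus musculus, strain Swiss Webster) for pharmacokinetics, read by LC-MS, at a dose of 50 mg/kg by the oral route (a higher number here means more compound in the circulation at the dose given, a lower number less compound in the circulation), compound 2 gives 1070 nM, the lower of the two numbers so far, while compound 1 gives 6670 nM. The next compound is compound 3 `O=C(Nc1ccc(F)c(-c2nc3ncc(C(F)(F)F)cc3[nH]2)c1)N1CCCC1`, where trifluoromethyl takes the place of 5-fluoropyridin-3-yl on an aromatic carbon: trifluoromethyl in place of 5-fluoropyridin-3-yl on an aromatic carbon. For the measured compounds named here, only one measured step bears on this change, a 6.2-fold lower number from compound 1 to compound 2 (0.79 log units; beyond the scatter). That step was modest but beyond the scatter, and it shows that this assay responds to a change of this group. Going by the values given here, it exchanged one aromatic ring for another, however, and no measured compound carries trifluoromethyl, so it gives no direct size for the new step. Among the compounds with values here, with compound 2 at the low end and the step from compound 1 as the only guide, a modest rise is expected, one that probably stays short of compound 1. The expected change is a 2.3-fold higher number from compound 2 to compound 3 (0.37 log units; beyond the scatter). Compound 3 is estimated at 2500 nM, with an expected range of 700 nM to 9000 nM.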

Compound 3, maximal plasma concentration: 1080 nM
For compound 3 the middle estimate is 2.3-fold (0.36 log units) above the measured one, within the range that was stated.
By their numbers in this assay, from the lowest: compounds 2 and 3 (each within the scatter of the next); then compound 1.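

In this assay, the step of a 1.0-fold higher number from compound 2 to compound 3 (0.00 log units; within the scatter) shows that the group on this aromatic carbon can lose its ring without any change beyond the scatter: trifluoromethyl, with no ring, cannot be told apart from 5-fluoropyridin-3-yl, which has one six-membered aromatic ring. The step of a 6.2-fold lower number from compound 1 to compound 3 (0.79 log units; beyond the scatter) is the same size as a 6.2-fold lower number from compound 1 to compound 2 (0.79 log units; beyond the scatter), so of the three groups only 3,4-difluorophenyl, in compound 1, stands apart, and the presence of an aromatic ring at this position does not by itself go with the larger number. No information is available that explains why compound 1 differs from the other two.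

The compounds shown leave open whether the larger number in compound 1 is tied to its two fluorines or to the all-carbon ring, which a plain phenyl or a 4-fluorophenyl at this carbon would help separate. On these data alone, it also remains open how a small non-aromatic group such as a nitrile, a methyl or an amine would compare with trifluoromethyl here.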